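Thiophene for dichlorophenyl in a histamine H2 agonist series

A few compounds are considered here, and "the series" means these few. Any claim that something is new, unique, unknown or untested is made for them only; others in the source may bear on it.

Measured compounds in a functional assay on cardiac atrium for agonist activity at histamine H2 receptor (Cavia porcellus); a lower number here means a smaller maximal response, a higher number a larger maximal response:
compound 1 `N=C(NCCCc1c[nH]cn1)NCCC(c1ccc(Cl)cc1)c1ccccn1` gives 1
compound 2 `N=C(NCCCc1c[nH]cn1)NCCC(c1ccc(Br)cc1)c1ccccn1` gives 1
compound 3 `N=C(NCCCc1c[nH]cn1)NCCC(c1ccc(Cl)c(Cl)c1)c1ccccn1` gives 1

Compound 3 stands level with compounds 1 and 2: the steps of no change at the digits printed from compound 1 to compound 3 (within the scatter) and no change at the digits printed from compound 2 to compound 3 (within the scatter) are both within the scatter, as is no change at the digits printed from compound 1 to compound 2 (within the scatter). Every measured change so far touches only the halogen pattern of the phenyl ring, and none shifts the maximal response.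

Compound 4 `N=C(NCCCc1c[nH]cn1)NCCC(c1ccccn1)c1cccs1` differs from compound 3 as follows: thiophen-2-yl in place of 3,4-dichlorophenyl on a saturated chain carbon bound to an aromatic carbon and a saturated chain carbon. Within the data shown here, no measured step exchanges one aromatic ring for another, so the three flat steps bear on it only indirectly; on that basis no step beyond the scatter in this assay is expected, though the exchange of the whole ring leaves more room for loss than the halogen swaps did.

For compound 4 the estimated value is 0.95, range 0.7 to 1, an expected step of a number 0.050 lower from compound 3 to compound 4 (within the scatter).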

Compound 4, intrinsic activity: the largest response reached, as a fraction of the reference agonist's: 1
Beside the measured number, compound 4's estimate is 0.050 below it; the measured number falls inside the stated range.
By their numbers in this assay, from the lowest: compounds 1, 2, 3 and 4 (each within the scatter of the next).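

In this assay, this saturated chain carbon accepts exchange of the whole aromatic ring, not only a change of halogen pattern: thiophen-2-yl in place of 3,4-dichlorophenyl gives no change at the digits printed from compound 3 to compound 4 (within the scatter). The exchange reads the same against 4-bromophenyl, with no change at the digits printed from compound 2 to compound 4 (within the scatter), and against 4-chlorophenyl, with no change at the digits printed from compound 1 to compound 4 (within the scatter). Nothing at hand accounts for this ring being accepted.

On these data alone, whether cyclohexyl, a non-aromatic ring, or a plain methyl at this carbon keeps the maximal response remains open. So does the effect of a carboxylic acid on the thiophene.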